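This account rests on a few compounds, and the source may have more. Where it says the series, first, only, none or still open, it means among the compounds named here.

Going by the values given here, in an ADME assay on MCF7 cells (Homo sapiens) for cytotoxicity, with a stated time of 72 h (a higher number here means a weaker inhibitor, a lower number a stronger inhibitor), compound 1 `COc1cccc(CNc2ncnc3c2ncn3C2CCCCO2)c1` gives 97000 nM, the only actual number so far. Compound 2 `COc1cccc(CNc2ncnc3c2ncn3C2CCCCO2)c1O` gives > 100000 nM, and this is a limit of the assay, not a number.

Compound 3 `COc1ccc(CNc2ncnc3c2ncn3C2CCCCO2)cc1OC` carries one change from compound 1: methoxy in place of hydrogen on an aromatic carbon. This is methoxy in place of hydrogen on an aromatic carbon, ortho to a methoxy group and para to a large group.

Among the compounds with values here, the one measured step that bears on this change is an at least 1.0-fold higher number from compound 1 to compound 2 (0.01 log units; that floor lies within the scatter), where hydroxy takes the place of hydrogen on an aromatic carbon. It is a different group, and its size is known only as a floor. Resting on that step, no shift beyond the scatter is expected in this assay, and the direction stays open. A limit reading is also a real possibility for the next measurement.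

The expected step is a 1.1-fold lower number from compound 1 to compound 3 (0.06 log units; within the scatter). For compound 3 the estimated value is 85000 nM, with an expected range of 35000 nM to 150000 nM.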

Compound 3, half-maximal inhibitory concentration: > 100000 nM
Compound 3 ended at the assay's limit; the forecaster's own chance of this, stated with the estimate: 45%; middle value at least 1.1-fold (0.07 log units) away from the limit.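

In this assay, methoxy on this carbon, ortho to a methoxy group and para to a large group, gives an at least 1.0-fold higher number from compound 1 to compound 3 (0.01 log units; that floor lies within the scatter), and the reading for compound 3 is a limit of the assay, not a number. Going by these compounds alone, this is the second addition to the aromatic ring of compound 1 to end without a measurable number, after the hydroxy of compound 2, and the methoxy here gives no reading lower than the one for compound 1, 97000 nM. The step cannot be read past its floor, and its true size stays hidden because the series already sits at the top of the assay's range: the limit of > 100000 nM in this assay, at which 2 of the 3 values shown sit.

On these data alone, whether an amine or a carboxylic acid on this same carbon would give a number clearly lower than that of compound 1 stays open. Also open, as far as these compounds go, is how far compound 3 really lies from compound 1, so the present readings rank neither the position nor the methoxy group against any alternative.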